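Swapping the Charged Ring at the Chain End

The compounds below may be only part of what the source reports. "The series", "measured", "known", "first", "only" and "open" are said of these compounds alone.

Compound 1, `Cc1cc(-n2cc(C(=O)Nc3cc(F)cc(F)c3)c(=O)c3ccc(N(C)C)nc32)ccc1OCCCCCCC[N+]1(C)CCCC1`, gives 35.9% in an assay on LX2 cells for inhibition of COL1A1 promoter (Homo sapiens), read by a luciferase reporter, with a stated time of 24 h, tested at 50 uM; on this read-out higher numbers stand for a stronger effect at the one concentration tested and lower numbers for a weaker effect.
Compound 2, `Cc1cc(-n2cc(C(=O)Nc3cc(F)cc(F)c3)c(=O)c3ccc(N(C)C)nc32)ccc1OCCCCCCC[N+]1(C)CCCCC1`, gives 54.4% in this assay.

Compound 2 stands highest of the two numbers: a number 18.5 percentage points higher from compound 1 to compound 2 (beyond the scatter). Compound 3, `Cc1cc(-n2cc(C(=O)Nc3cc(F)cc(F)c3)c(=O)c3ccc(N(C)C)nc32)ccc1OCCCCCCC[n+]1ccccc1`, differs from compound 2 by a group of 6 heavy atoms (5 carbon, 1 nitrogen; one six-membered aromatic ring with 1 hetero atom) in place of a group of 7 heavy atoms (6 carbon, 1 nitrogen; one six-membered non-aromatic ring with 1 hetero atom), on a saturated chain carbon, seven bonds along the chain from an oxygen on an aromatic ring. Within the data shown here, the single measured step concerns a different change, a larger non-aromatic ring replacing a smaller one, and it was modest. Among the measured compounds shown here, no measured step shows an aromatic ring entering in place of a non-aromatic one, so a step of no size beyond the scatter is expected, a number 6.4 percentage points lower from compound 2 to compound 3 (within the scatter). Compound 3 is therefore estimated at 48%, between 30% and 66%.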

Compound 3, a percentage reported as inhibition, at one concentration (the size of the read-out at that concentration, not a potency): 55%
Beside the measured number, compound 3's estimate is 7 percentage points below it; measured number inside the range.
By their numbers in this assay, from the lowest: compound 1; then compounds 2 and 3 (each within the scatter of the next).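

The step of a number 0.6 percentage points higher from compound 2 to compound 3 (within the scatter) shows that, in this assay, an aromatic six-membered ring can take the place of the non-aromatic one at the chain end without a change beyond the usual scatter. The step of a number 19.1 percentage points higher from compound 1 to compound 3 (beyond the scatter) then sets the five-membered non-aromatic ring apart from both six-membered rings, among these three compounds only. Nothing measured here gives a reason for this.

Still open, from the compounds shown here alone, is how a seven-membered ring or an open trimethylammonium group would read at this chain end. Also open, going by these compounds, is whether the pyridinium ring keeps its value on a shorter or longer chain.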